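Biaryl arm: methyl ester in place of a furan

The compounds below may be only part of what the source reports. "The series", "measured", "known", "first", "only" and "open" are said of these compounds alone.

Compound 1 `Cc1ccccc1-n1nc(C)c2c1NC(=O)[C@H](C)S[C@@H]2c1ccc(-c2ccoc2)cc1`: 3500 nM
Compound 2 `COc1ccc(C2SC(C)C(=O)Nc3c2c(C)nn3-c2ccccc2C)c(OC)c1`: 10500 nM
Compound 3 `Cc1ccccc1-n1nc(C)c2c1NC(=O)[C@H](C)S[C@@H]2c1ccc(-c2ccc(C(=O)O)cc2)cc1`: "not active" (no number reported)

In an assay on isolated protein for agonist activity at Bile acid receptor (Homo sapiens), read by AlphaScreen, with a stated time of 30 min (on this read-out higher numbers stand for an effect only at larger amounts of compound and lower numbers for an effect already at smaller amounts), compound 1 gives 3500 nM, the lowest of the two numbers reported. Compound 2 gives 10500 nM, and the gap between the two lies beyond the scatter. Compound 3 is reported as "not active" (no number reported), without a number. Compound 4 `COC(=O)c1ccc(-c2ccc([C@H]3S[C@@H](C)C(=O)Nc4c3c(C)nn4-c3ccccc3C)cc2)cc1` differs from compound 1 in one place: 4-(methoxycarbonyl)phenyl in place of furan-3-yl on an aromatic carbon. Within the data shown here, no measured pair shows this change, so its effect is unknown. Compound 3 carries a different group in the same place and is not active, whereas the entering group of compound 4, like the furan it replaces, has no net charge. The step of a 1.4-fold higher number from compound 1 to compound 4 (0.15 log units; within the scatter) is expected to be small, toward a higher number or none beyond the scatter. Compound 4 is estimated at 5000 nM, between 1500 nM and 20000 nM.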

Compound 4, half-maximal effective concentration: "not active" (no number reported)
No number was reported for compound 4; there is nothing to compare the estimate with.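

Compound 4 has no reported number, so no step from compound 1 to compound 4 can be read, and no available evidence explains the result. The compounds shown leave open whether any other group in this place would give a lower number than compound 1.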